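Anilide series at the assay limit: sulfamoyl replacement

The source may hold more compounds than are shown below. What is called first, only, known or untested is meant among the compounds shown, and "the series" means these compounds.

Measured so far in an assay on a protein complex (Cavia porcellus) with sulfonylurea receptors; K-ATP channels (Homo sapiens) as the target; on this read-out higher numbers stand for weaker inhibition and lower numbers for stronger inhibition:
compound 1 `CC(O)(C(=O)Nc1ccc(Sc2ccccc2)cc1)C(F)(F)F` gives > 30000 nM
compound 2 `CC(O)(C(=O)Nc1ccc([C@@H](O)c2ccccc2)cc1)C(F)(F)F` gives > 30000 nM
compound 3 `CC(O)(C(=O)Nc1ccc([C@H](O)c2ccccc2)cc1)C(F)(F)F` gives > 30000 nM

Each of these values is a limit of this assay, not a number. Compound 3 therefore stands at the limit, and no order among the three can be read. The steps a step that the two limits leave unreadable from compound 1 to compound 2, a step that the two limits leave unreadable from compound 1 to compound 3 and a step that the two limits leave unreadable from compound 2 to compound 3 stay unreadable because of the limit of > 30000 nM in this assay, at which 3 of the 3 values shown sit; for the last pair the fact that one of compounds 2 and 3 is drawn with a defined configuration and the other without, at the place where they differ also applies.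

Compound 4 `CN(C)S(=O)(=O)c1ccc(NC(=O)C(C)(O)C(F)(F)F)cc1` carries the change (dimethylsulfamoyl in place of hydroxy(phenyl)methyl on an aromatic carbon). Within the data shown here, no measured step touches the dimethylsulfamoyl group, so nothing read so far sets the size or direction of the step in this assay. Compound 4 is expected near 20000 nM, within 3000 nM to 60000 nM. The estimated step of an at least 1.5-fold lower number from compound 3 to compound 4 (0.17 log units; that floor lies within the scatter) is thus expected to remain hard to read against the limit.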

Compound 4, half-maximal inhibitory concentration: 480 nM
For compound 4 the middle estimate is 42-fold (1.62 log units) above the measured one; measured number below the stated range.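

In this assay, this place on an aromatic carbon responds to substitution once dimethylsulfamoyl enters, with an at least 62-fold lower number from compound 3 to compound 4 (1.79 log units; beyond the scatter), an at least 62-fold lower number from compound 2 to compound 4 (1.79 log units; beyond the scatter) and an at least 62-fold lower number from compound 1 to compound 4 (1.79 log units; beyond the scatter). The entering group has no ring and no hydrogen-bond donor, so neither is required here for a value below the limit. These steps are floors only, and the steps among compounds 1, 2 and 3 cannot be read, because of this: the limit of > 30000 nM in this assay, at which 3 of the 4 values shown sit.

From the compounds shown here alone, whether a plain sulfamoyl without the two methyl groups, a carboxylic acid or a longer chain on the sulfamoyl nitrogen would keep or shift the value stays open.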